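Dimethylamino in place of methylpiperazinyl on the shared core

The compounds below may be only part of what the source reports. "The series", "measured", "known", "first", "only" and "open" are said of these compounds alone.

Measured so far:
Compound 1 `Cc1ccc2nc(N3CCNC(C)C3)nc(NCc3ccc(C(=O)NC4CCN(Cc5ccc(F)cc5)CC4)cc3)c2c1` gives 2000 nM in a functional assay on HCT-116 cells (Homo sapiens) for inhibition, read by luminescence and resazurin assay, with a stated time of 3 days; a higher number here means a weaker inhibitor, a lower number a stronger inhibitor.
Compound 2 `CNc1nc(NCc2ccc(NC(=O)c3ccncc3)cc2)c2ccccc2n1` reaches only the limit of this assay, > 20000 nM.
Compound 3 `CCCNc1nc(NCc2ccc(NC(=O)c3ccc(F)cc3)cc2)c2ccccc2n1` gives 1700 nM in this assay.

Compound 1 has the higher of the two numbers in this assay, though compound 3 sits within the scatter of it, so no order between compound 1 and compound 3 can be read. Among the compounds with values here, the value of compound 2 is a limit, not a number; it is the one such value here, (the limit of > 20000 nM in this assay, at which 1 of the 3 values shown sits).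

Compound 4 `Cc1ccc2nc(N(C)C)nc(NCc3ccc(C(=O)NC4CCN(Cc5ccc(F)cc5)CC4)cc3)c2c1` differs from compound 1 in one place: dimethylamino in place of 3-methylpiperazin-1-yl on an aromatic carbon. No step between measured compounds separates these two groups, so the size of this step is not shown. Compound 4 is expected to give about 4000 nM, between 1500 nM and 12000 nM. The expected step, a 2.0-fold higher number from compound 1 to compound 4 (0.30 log units; within the scatter), is thought to be a modest move toward a higher number, close to the edge of the scatter.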

Compound 4, half-maximal inhibitory concentration: 800 nM
For compound 4 the middle estimate is 5.0-fold (0.70 log units) above the measured one, and the stated range ends above it.
By their numbers in this assay, from the lowest: compound 4; then compounds 3 and 1 (each within the scatter of the next). At a limit, above all of these: compound 2.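

Within the data shown here, on the aromatic carbon between two ring nitrogen atoms, replacing 3-methylpiperazin-1-yl with dimethylamino gives a 2.5-fold lower number from compound 1 to compound 4 (0.40 log units; beyond the scatter) in this assay, so the earlier compounds' single reading of this core now has a measured change at this position. On this core, neither the six-membered non-aromatic ring nor its hydrogen-bond donor is needed to keep activity in this assay, and the smaller group with no ring does better than the larger one. Nothing measured here accounts for this step.

The compounds shown leave open whether the step follows from losing the ring, losing the donor or the lower count of heavy atoms. A pyrrolidine or morpholine ring on the same carbon would help to separate these, and a longer chain on the nitrogen would show how far the trend holds.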